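A new aromatic group on compound 3

The source may report more compounds than this note shows. Statements on the series, on what has been measured and on what is new or still open speak of the compounds shown alone.

Compound 1 `COc1ccc(C(=O)/C=C/c2ccccc2)cc1S(=O)(=O)Nc1c(N)nc(SC)[nH]c1=O`: 17000 nM
Compound 2 `COc1ccc(C(=O)/C=C/c2ccc(Cl)cc2)cc1S(=O)(=O)Nc1c(N)nc(SC)[nH]c1=O`: 13000 nM
Compound 3 `COc1ccc(C(=O)/C=C/c2ccc(C)cc2)cc1S(=O)(=O)Nc1c(N)nc(SC)[nH]c1=O`: 7200 nM

In an ADME assay on NIH3T3 cells (Mus musculus) for cytotoxicity, read by MTT assay, with a stated time of 48 h (on this read-out lower numbers stand for higher toxicity in this test and higher numbers for lower toxicity in this test), compound 3 gives 7200 nM. That number stands clearly apart from compound 1, a 2.4-fold lower number from compound 1 to compound 3 (0.37 log units; beyond the scatter), but not from compound 2, a 1.8-fold lower number from compound 2 to compound 3 (0.26 log units; within the scatter). Compound 4 `COc1ccc(C(=O)/C=C/c2cc(OC)c(OC)c(OC)c2)cc1S(=O)(=O)Nc1c(N)nc(SC)[nH]c1=O` has a larger group at one place: 3,4,5-trimethoxyphenyl in place of 4-methylphenyl on a double-bonded chain carbon bound to a double-bonded chain carbon. The nearest evidence is two single swaps on an aromatic carbon, a 1.3-fold lower number from compound 1 to compound 2 (0.12 log units; within the scatter) and a 2.4-fold lower number from compound 1 to compound 3 (0.37 log units; beyond the scatter). Both are small, yet neither involves a methoxy group, so the data favour no firm direction, and only a small step is expected in this assay. The expected change is a 1.3-fold higher number from compound 3 to compound 4 (0.10 log units; within the scatter). The estimated value for compound 4 is 9000 nM, with an expected range of 3000 nM to 25000 nM.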

Compound 4, concentration lethal to 50% of the cells: 2100 nM
For compound 4 the middle estimate is 4.3-fold (0.63 log units) above the measured one; the measured number lies below the stated range.
By their numbers in this assay, from the lowest: compound 4; then compounds 3, 2 and 1 (each within the scatter of the next, the first and the last beyond it).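

In this assay, replacing the group on a double-bonded chain carbon bound to a double-bonded chain carbon with 3,4,5-trimethoxyphenyl gives steps beyond the scatter from all three earlier compounds (a 3.4-fold lower number from compound 3 to compound 4 (0.54 log units; beyond the scatter); a 6.2-fold lower number from compound 2 to compound 4 (0.79 log units; beyond the scatter); an 8.1-fold lower number from compound 1 to compound 4 (0.91 log units; beyond the scatter)). For the compounds shown here, this makes compound 4 the most toxic of the four in this test, so this position can respond to a larger group more strongly than the single chloro and methyl swaps showed. No measurement at hand explains the shift.

From the compounds shown here alone, it remains open whether all three methoxy groups are needed, or whether a single methoxy group or an amine on the ring would give a similar number.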